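A few compounds are considered here, and "the series" means these few. Any claim that something is new, unique, unknown or untested is made for them only; others in the source may bear on it.

Compound 1, with the structure `Cc1oc(-c2ccc(Cl)cc2)nc1CN1CCC(C(=O)NCCCN2C[C@H](C)C[C@H](C)C2)CC1`, is the reference point for this small set. In a physicochemical assay for permeability, using PAMPA (a higher number here means that the compound crosses the layer faster, a lower number that the compound crosses the layer more slowly), compound 1 gives > 635 10^-6 cm/s, which is a limit of the assay rather than a number. Compound 2, with the structure `Cc1oc(-c2c(Cl)cccc2Br)nc1CN1CCC(C(=O)NCCCN2C[C@H](C)C[C@H](C)C2)CC1`, has no reading in this assay: for compound 2 the result is "not determined" (no result reported). Compound 3, with the structure `Cc1cccc(Cl)c1-c1nc(CN2CCC(C(=O)NCCCN3CCC(C(C)C)CC3)CC2)c(C)o1`, is in the same position, and for compound 3 the entry in this assay is likewise "not determined" (no result reported). So compound 2 stands without any number of its own, and the only value in the set is the limit reached by compound 1, as the limit of > 635 10^-6 cm/s in this assay, at which 1 of the 3 values shown sits, records.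

The step from compound 2 to compound 4 replaces one aryl group on the shared core, (2,4-dimethylphenyl in place of 2-bromo-6-chlorophenyl on an aromatic carbon). Compound 4 has the structure `Cc1ccc(-c2nc(CN3CCC(C(=O)NCCCN4C[C@H](C)C[C@H](C)C4)CC3)c(C)o2)c(C)c1`. Among the compounds with values here, with no step between measured compounds in hand, no direction can be read off, and no change beyond the usual scatter of this assay is expected from the swap of one carbon-only aromatic ring for another. Compound 4 is therefore expected to sit near the limit that compound 1 reached, at an estimated 500 10^-6 cm/s in this assay, within a range from 200 10^-6 cm/s to 700 10^-6 cm/s.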

Compound 4, apparent permeability: 353 10^-6 cm/s
Compound 4: the middle estimate sits 1.4-fold (0.15 log units) above what was measured; measured number inside the range.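

In this assay, within the data shown here, compound 4 gives 353 10^-6 cm/s, the first true number in this set for a group on the aromatic carbon that lies next to the ring nitrogen and next to the ring oxygen. Compound 1, which carries 4-chlorophenyl at that same place, stays at a limit of the assay and not a number: the limit of > 635 10^-6 cm/s in this assay, at which 1 of the 4 values shown sits. Set against that limit, 2,4-dimethylphenyl in place of 4-chlorophenyl comes out as an at least 1.7-fold lower number from compound 1 to compound 4 (0.25 log units; that floor lies within the scatter), so only a floor on this change is known, and that floor does not yet show a shift beyond the scatter, although the real gap could be larger.

On these data alone, the size of the step from 4-chlorophenyl to 2,4-dimethylphenyl stays open, and so does any comparison with the 2-bromo-6-chlorophenyl of compound 2, which has no reading to set against compound 4. Also open, as far as these compounds go, is how this read-out would respond at the same place to an aromatic ring carrying a carboxylic acid or an amine, or to a ring with a nitrogen atom in it.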